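A few compounds are considered here, and "the series" means these few. Any claim that something is new, unique, unknown or untested is made for them only; others in the source may bear on it.

Measured compounds:
compound 1, `CC#C[C@H]1CN(S(=O)(=O)c2ccc(N)nc2)CCN1c1ccc([C@@](O)(CO)C(F)(F)F)cc1`: 89 nM
compound 2, `CC#CCC(O)(c1ccc(N2CCN(S(=O)(=O)c3ccc(N)nc3)C[C@@H]2C#CC)cc1)C(F)(F)F`: 137 nM
compound 3, `CC#C[C@H]1CN(S(=O)(=O)c2ccc(N)nc2)CCN1c1ccc(S(C)(=N)=O)cc1`: 704 nM

In an assay on cells (Hepatocyte) for inhibition of glucokinase regulatory protein (Mus musculus), with stated times of 20 min and 40 min (on this read-out lower numbers stand for an effect already at smaller amounts and higher numbers for an effect only at larger amounts of compound), compound 1 stands at the lowest of the three numbers. Compound 2 sits within the scatter of it, a 1.5-fold higher number from compound 1 to compound 2 (0.19 log units; within the scatter), while compound 3 lies beyond it, a 7.9-fold higher number from compound 1 to compound 3 (0.90 log units; beyond the scatter).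

Compound 4, `CC#C[C@H]1CN(S(=O)(=O)c2ccc(N)nc2)CCN1c1ccc(C(=O)NC)cc1`, is yet to be measured in this assay. a group of 4 heavy atoms (2 carbon, 1 nitrogen, 1 oxygen; no ring) in place of a group of 8 heavy atoms (3 carbon, 2 oxygen, 3 fluorine; no ring), on an aromatic carbon The measured step most like this one is the step from compound 1 to compound 3, also a group of 4 heavy atoms in place of the same group of 8 heavy atoms on the same aromatic carbon: a 7.9-fold higher number from compound 1 to compound 3 (0.90 log units; beyond the scatter). The step of a 5.1-fold higher number from compound 2 to compound 3 (0.71 log units; beyond the scatter) points the same way. Both replacements of the group of 8 heavy atoms by a group of 4 heavy atoms gave a modest rise, so a rise of similar size is expected for compound 4, with the caution that methylcarbamoyl is not the group that enters in compound 3 and need not behave alike.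

The estimate for compound 4 in this assay is 450 nM, with a range of 150 nM to 1400 nM. The expected step, a 5.1-fold higher number from compound 1 to compound 4 (0.70 log units; beyond the scatter), is beyond the scatter but modest.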

Compound 4, half-maximal effective concentration: 4050 nM
The estimate for compound 4 lay 9.0-fold (0.95 log units) below the measured number; the measured number lies above the stated range.
By their numbers in this assay, from the lowest: compounds 1 and 2 (each within the scatter of the next); then compound 3; then compound 4.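

In this assay, the aromatic carbon para to a large group tolerates less than compound 3 suggested: methylcarbamoyl there gives a 46-fold higher number from compound 1 to compound 4 (1.66 log units; beyond the scatter) and a 30-fold higher number from compound 2 to compound 4 (1.47 log units; beyond the scatter), both large steps where the earlier replacements were modest at most. Entering groups with the same heavy-atom count also do not read alike, as a 5.8-fold higher number from compound 3 to compound 4 (0.76 log units; beyond the scatter) shows, so that count alone does not set the number at this position. Nothing available bears on the cause of these steps.

The compounds shown leave open whether a carboxylic acid or a primary amide at this position would stand nearer compound 3 or compound 4. They also leave open whether a tertiary alcohol without trifluoromethyl would hold the level of compound 1 and compound 2.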